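A few compounds are considered here, and "the series" means these few. Any claim that something is new, unique, unknown or untested is made for them only; others in the source may bear on it.

Measured so far:
- compound 1 `Cc1cc(C)c(CN2CCc3ccc(O[C@@H]4CCOC4)c(Cl)c3C2=O)c(=O)[nH]1`: 512 nM
- compound 2 `Cc1cc(C)c(CN2CCc3c(F)cc(O[C@@H]4CCOC4)c(Cl)c3C2=O)c(=O)[nH]1`: 1030 nM

In a functional assay on KARPAS-422 cells (Homo sapiens) for inhibition, with a stated time of 72 h (a lower number here means a stronger inhibitor, a higher number a weaker inhibitor), compound 2 lies within the scatter of compound 1, the only other measured point. Compound 3 `Cc1cc(C)c(CN2CCc3c(C)cc(O[C@@H]4CCOC4)c(Cl)c3C2=O)c(=O)[nH]1` differs from compound 2 by methyl in place of fluoro on an aromatic carbon. Among the measured compounds shown here, the one measured step bearing on this is a 2.0-fold higher number from compound 1 to compound 2 (0.30 log units; within the scatter), fluoro in place of hydrogen on an aromatic carbon, and it stays within the scatter. No methyl has been measured there, so no direction is expected with confidence. The estimated step is a 1.3-fold lower number from compound 2 to compound 3 (0.11 log units; within the scatter), expected to stay within the scatter. For compound 3 the expected value is 800 nM, with an estimated range of 300 nM to 2200 nM.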

Compound 3, half-maximal inhibitory concentration: 406 nM
For compound 3 the middle estimate is 2.0-fold (0.29 log units) above the measured one; the measured number falls inside the stated range.
By their numbers in this assay, from the lowest: compounds 3, 1 and 2 (each within the scatter of the next, the first and the last beyond it).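

In this assay, among the compounds shown here, methyl in place of fluoro gives a 2.5-fold lower number from compound 2 to compound 3 (0.40 log units; beyond the scatter) and is the only step so far beyond the scatter, though a modest one. Methyl in place of hydrogen gives a 1.3-fold lower number from compound 1 to compound 3 (0.10 log units; within the scatter) and stays within the scatter, so this position carries a methyl with no readable change from hydrogen, and neither substituent separates from hydrogen beyond the scatter. No measured information bears on the cause of the fluoro to methyl step.

Still open, on these data alone, is how this position responds to a group larger than methyl, such as ethyl or methoxy, or to an amine. Only these three substituents and this one cell read-out are shown.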